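Phenyl for chloro on the pyridazinone arm of compound 2

The compounds below may be only part of what the source reports. "The series", "measured", "known", "first", "only" and "open" are said of these compounds alone.

Measured so far:
compound 1 `CC1C(=O)c2nc(CN3N=C(c4ccccc4)CCC3=O)[nH]c2N(C)C1=O` gives 53800 nM;
compound 2 `CCCC1C(=O)c2nc(CN3N=C(Cl)CCC3=O)[nH]c2N(C)C1=O` gives 9200 nM.

Among the measured compounds shown here, in an assay on isolated protein for binding affinity to adenosine receptor A1 (Homo sapiens) (a lower number here means a stronger inhibitor, a higher number a weaker inhibitor), compound 2 stands lowest of the two numbers known; the nearest number is that of compound 1, and the gap to compound 1 lies beyond the usual scatter. Compound 3 `CCCC1C(=O)c2nc(CN3N=C(c4ccccc4)CCC3=O)[nH]c2N(C)C1=O` has not been measured. It differs from compound 2 in one place: phenyl in place of chloro on a carbon with a double bond to nitrogen. For the measured compounds named here, no step with this change alone is known. Going by the values given here, compound 1 carries the same phenyl group, but it differs from compound 2 in a second place as well, so its value cannot be read as the effect of the phenyl alone; it shows only that a phenyl-bearing analogue of this series has been measured at a much higher number. The expectation for compound 3 is therefore a step toward a higher number, of moderate size, a 2.2-fold higher number from compound 2 to compound 3 (0.34 log units; beyond the scatter), with real uncertainty about whether it exceeds the scatter. Compound 3 is expected to give 20000 nM, estimated within 6000 nM to 70000 nM.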

Compound 3, inhibition constant: 2270 nM
The estimate for compound 3 lay 8.8-fold (0.95 log units) above the measured number; measured number outside the range, below it.
By their numbers in this assay, from the lowest: compound 3; then compound 2; then compound 1.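

In this assay, phenyl in place of chloro on a carbon with a double bond to nitrogen gives a 4.1-fold lower number from compound 2 to compound 3 (0.61 log units; beyond the scatter), which shows that this carbon of the six-membered non-aromatic ring accepts the larger aromatic ring and that the number falls with it. With the phenyl held constant, compound 3 also separates the second change that had been tied up in compound 1: ethyl in place of hydrogen on a saturated chain carbon bound to a saturated ring carbon gives a 24-fold lower number from compound 1 to compound 3 (1.37 log units; beyond the scatter), the larger of the two steps. Nothing among the data explains the direction or size of either step.

From the compounds shown here alone, only chloro and phenyl are seen on this carbon, so it remains open how a methoxy group, an amine or a phenyl ring bearing a fluorine would compare there. Going by these compounds, it is equally open whether a longer chain in place of the ethyl would lower the number further, and whether the phenyl step would keep its size on the shorter chain of compound 1.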